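Series notes: benzyl in place of phenyl

The source may hold more compounds than are shown below. What is called first, only, known or untested is meant among the compounds shown, and "the series" means these compounds.

In an ADME assay on RAW264.7 cells (Mus musculus) for cytotoxicity, read by MTT assay, with a stated time of 24 h (on this read-out lower numbers stand for higher toxicity in this test and higher numbers for lower toxicity in this test), compound 1 (`CC/C=C\C[C@H]1C(=O)C=C[C@H]1CC(=O)OCC`) gives 146 uM, compound 2 (`CC/C=C\C[C@H]1C(=O)C=C[C@H]1CC(=O)OCCCC`) gives 31 uM and compound 3 (`CC/C=C\C[C@H]1C(=O)C=C[C@H]1CC(=O)Oc1ccccc1`) gives 158 uM. Compound 3 stands level with compound 1, as a 1.1-fold higher number from compound 1 to compound 3 (0.03 log units; within the scatter) lies within the scatter, while a 5.1-fold higher number from compound 2 to compound 3 (0.71 log units; beyond the scatter) lies beyond it.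

The next structure is compound 4 (`CC/C=C\C[C@H]1C(=O)C=C[C@H]1CC(=O)OCc1ccccc1`), with the change benzyl in place of phenyl on an oxygen next to a carbonyl group. Going by the values given here, no measured step covers this exact swap, so two steps serve as guides. With phenyl in place of ethyl, a 1.1-fold higher number from compound 1 to compound 3 (0.03 log units; within the scatter) shows no change beyond the scatter. With the butyl of compound 2, a 4.7-fold lower number from compound 1 to compound 2 (0.67 log units; beyond the scatter) shows a modest drop, so a larger group on this oxygen does not always leave the number unchanged.

A small move to a lower number is therefore expected, and the expected step, a 1.9-fold lower number from compound 3 to compound 4 (0.27 log units; within the scatter), may not clear the scatter. For compound 4 the estimated value is 85 uM, with an expected range of 35 uM to 170 uM.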

Compound 4, half-maximal toxic concentration: 31 uM
Compound 4: middle estimate off by 2.7-fold (0.44 log units), on the high side; measured number below the stated range.
By their numbers in this assay, from the lowest: compounds 2 and 4 (each within the scatter of the next); then compounds 1 and 3 (each within the scatter of the next).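

Benzyl in place of phenyl on an oxygen next to a carbonyl group gives a 5.1-fold lower number from compound 3 to compound 4 (0.71 log units; beyond the scatter) in this assay, so these two groups are not interchangeable here, although each carries one six-membered aromatic ring of carbon only. Benzyl and butyl give the same printed number, with no change at the digits printed from compound 2 to compound 4 (within the scatter), and a 4.7-fold lower number from compound 1 to compound 4 (0.67 log units; beyond the scatter) shows that a low number at this position is not confined to a plain chain or to an aromatic group. A link between a larger group and a lower number fits compound 2 and compound 4, but compound 3 goes against it.

Nothing available accounts for the difference between phenyl and benzyl at this position. From the compounds shown here alone, whether phenethyl or a longer chain on this oxygen would give a number nearer compound 4 or compound 3 remains open.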